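This account rests on a few compounds, and the source may have more. Where it says the series, first, only, none or still open, it means among the compounds named here.

Working notes on the series. In a functional assay on K562 cells (Homo sapiens) for antiproliferative activity, read by CellTiter-Glo and CCK-8 assay, with a stated time of 72 h (on this read-out lower numbers stand for stronger inhibition of growth and higher numbers for weaker inhibition of growth), compound 1 `CNc1cc(Nc2ncc3c(n2)N(C)C(=O)N(c2cc(NC(=O)c4cccc(C(F)(F)F)c4)ccc2C)C3)ccc1C` gives 19 nM, the lowest number of the three measured, though compound 2 `Cc1cc(C)cc(C(=O)Nc2ccc(C)c(N3Cc4cnc(Nc5ccc(C)c(N)c5)nc4N(C)C3=O)c2)c1` with 26 nM differs only within the usual scatter; compound 3 `Cc1ccc(Nc2ncc3c(n2)N(C)C(=O)N(c2cc(NC(=O)c4cc(C(C)(C)C)cc(C(C)(C)C)c4)ccc2C)C3)cc1N` with 1300 nM sits far higher, beyond the scatter. Within the data shown here, no pair of measured compounds differs in a single place, so no measured step guides the next change. Compound 4 `Cc1ccc(Oc2ncc3c(n2)N(C)C(=O)N(c2cc(NC(=O)c4cccc(C(F)(F)F)c4)ccc2C)C3)cc1N` differs from compound 1 in one place: 3-amino-4-methylphenoxy in place of (4-methyl-3-(methylamino)phenyl)amino on an aromatic carbon. The change removes one hydrogen-bond donor at that position, and nothing measured here probes that linker. The step from compound 1 to compound 4 is expected to run toward a higher number and beyond the scatter, by an 11-fold higher number from compound 1 to compound 4 (1.02 log units; beyond the scatter). Compound 4 is estimated at 200 nM, with a range of 40 nM to 1500 nM.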

Compound 4, concentration for 50% growth inhibition: 13 nM
Compound 4: the middle estimate sits 15-fold (1.19 log units) above what was measured; measured number below the stated range.
By their numbers in this assay, from the lowest: compounds 4, 1 and 2 (each within the scatter of the next); then compound 3.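

In this assay, the aromatic carbon between two ring nitrogen atoms accepts 3-amino-4-methylphenoxy in place of (4-methyl-3-(methylamino)phenyl)amino, giving a 1.5-fold lower number from compound 1 to compound 4 (0.16 log units; within the scatter) and leaving the two compounds indistinguishable. The entering group has one hydrogen-bond donor fewer, so the donor count of the leaving group is not required to keep growth inhibition at this level. No measurement on hand gives a reason for this result.

Because the oxygen link and the primary amine enter together, their separate contributions stay unresolved. Also open, going by these compounds, is whether a sulfur link or a methylene link at this carbon would give a similar number.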